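This account rests on a few compounds, and the source may have more. Where it says the series, first, only, none or still open, it means among the compounds named here.

Measured so far in an assay on isolated protein for binding affinity to histamine H2 receptor (Homo sapiens); on this read-out lower numbers stand for stronger inhibition and higher numbers for weaker inhibition:
compound 1 `O=C(c1ccc(OCCCN2CC[C@H](NS(=O)(=O)c3ccccc3)C2)cc1)C1CC1` gives 1200 nM
compound 2 `O=C(c1ccc(OCCCN2CC[C@H](NS(=O)(=O)c3cccc(Cl)c3)C2)cc1)C1CC1` gives 700 nM
compound 3 `CC(C)(C)c1ccc(S(=O)(=O)N[C@H]2CCN(CCCOc3ccc(C(=O)C4CC4)cc3)C2)cc1` gives 730 nM

Compound 3 stands second highest of the three numbers. Its nearest neighbour is compound 2: a 1.0-fold higher number from compound 2 to compound 3 (0.02 log units; within the scatter). The furthest is compound 1: a 1.6-fold lower number from compound 1 to compound 3 (0.22 log units; within the scatter). All three compounds therefore sit within the usual scatter of one another, and none of them can be called the strongest or the weakest.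

Compound 4 `Cc1ccccc1S(=O)(=O)N[C@H]1CCN(CCCOc2ccc(C(=O)C3CC3)cc2)C1` is not yet measured. It differs from compound 3 in a single place: 2-methylphenyl in place of 4-(tert-butyl)phenyl on a sulfonyl sulfur. The shared core is unchanged. Going by the values given here, three measured steps bear on this kind of change, each a swap of the group on the sulfonyl sulfur: a 1.7-fold lower number from compound 1 to compound 2 (0.23 log units; within the scatter), a 1.6-fold lower number from compound 1 to compound 3 (0.22 log units; within the scatter) and a 1.0-fold higher number from compound 2 to compound 3 (0.02 log units; within the scatter). Each of them stayed within the scatter, whether hydrogen gave way to chloro or to tert-butyl, or 3-chlorophenyl to 4-(tert-butyl)phenyl. Among the compounds with values here, no measured compound carries a 2-methylphenyl, so the new group itself is unanchored. By analogy to the three steps, no step beyond the scatter is expected in this assay, in either direction. For compound 4 the expected value is 1000 nM, within 400 nM to 2500 nM. The step this expectation implies is a 1.4-fold higher number from compound 3 to compound 4 (0.14 log units; within the scatter).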

Compound 4, inhibition constant: 2200 nM
For compound 4 the middle estimate is 2.2-fold (0.34 log units) below the measured one, and the stated range covers the measured number.
By their numbers in this assay, from the lowest: compounds 2, 3, 1 and 4 (each within the scatter of the next, the first and the last beyond it).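

In this assay the group on the sulfonyl sulfur now produces steps beyond the scatter, which none of the earlier swaps there did: a 3.0-fold higher number from compound 3 to compound 4 (0.48 log units; beyond the scatter) with 2-methylphenyl in place of 4-(tert-butyl)phenyl, and a 3.1-fold higher number from compound 2 to compound 4 (0.50 log units; beyond the scatter) with 2-methylphenyl in place of 3-chlorophenyl. The position is therefore not indifferent to its substituent, though the effect is modest and appears only between these pairs, since a 1.8-fold higher number from compound 1 to compound 4 (0.26 log units; within the scatter) stays within the scatter, as do the steps from compound 1 to compound 2 and to compound 3. No measured evidence is at hand that would account for these differences.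

Going by these compounds alone, compound 4 is the only methyl compound in the set, so it remains open whether the steps follow from the methyl group itself or from where it stands on the aromatic ring. Also open, on these data alone, is how this assay would read for a cyclohexyl group on the sulfonyl sulfur, or for an aromatic ring carrying an amine or a carboxylic acid.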